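Moving a methyl group: from 4-methylphenyl to 3-methylphenyl

The source may report more compounds than this note shows. Statements on the series, on what has been measured and on what is new or still open speak of the compounds shown alone.

In an ADME assay on BJ cells (Homo sapiens) for cytotoxicity, with a stated time of 72 h (on this read-out lower numbers stand for an effect already at smaller amounts and higher numbers for an effect only at larger amounts of compound), compound 1 `Cc1nn(-c2ccccc2)c2nc(-c3ccccc3)c(C#N)c(-c3ccccc3O)c12` gives > 23000 nM, which is a limit of the assay and not a number. For the measured compounds named here, compound 2 `Cc1ccc(-c2nc3c(c(C)nn3-c3ccccc3)c(-c3ccccc3O)c2C#N)cc1` gives 22200 nM, the only true number so far, and the sole other reading is the limit of > 23000 nM in this assay, at which 1 of the 2 values shown sits.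

Compound 3 `Cc1cccc(-c2nc3c(c(C)nn3-c3ccccc3)c(-c3ccccc3O)c2C#N)c1` has the same atoms as compound 2, joined differently: 3-methylphenyl in place of 4-methylphenyl on an aromatic carbon. The methyl group therefore stays on the same phenyl group but changes its place on it, giving 3-methylphenyl in place of 4-methylphenyl.

Going by the values given here, only one measured step bears on this change: an at least 1.0-fold lower number from compound 1 to compound 2 (0.01 log units; that floor lies within the scatter). It is a guide of limited strength, since it adds a methyl group rather than moving one, and only a floor is known for its size. Among the compounds with values here, that floor lies within the scatter, so nothing measured so far points to a real shift in either direction.

No step beyond the scatter is expected in this assay, and the estimated step is a 1.1-fold lower number from compound 2 to compound 3 (0.02 log units; within the scatter). For compound 3, the estimated value is 21000 nM, with an expected range from 11000 nM to 32000 nM.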

Compound 3, half-maximal effective concentration: > 20000 nM
Compound 3: a limit, no number; the forecaster's own chance of this, stated with the estimate: 40%; the middle value lies beyond the limit too.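

In this assay compound 3 gives > 20000 nM, which is a limit of the assay and not a number. For the compounds shown here, no step from compound 2 to compound 3 or from compound 1 to compound 3 can be read. The compounds shown leave open whether 3-methylphenyl in place of 4-methylphenyl changes the read-out at all.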